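Diethoxy swap on the dimethoxy compound 3

The source may hold more compounds than are shown below. What is called first, only, known or untested is meant among the compounds shown, and "the series" means these compounds.

Measured in a functional assay on DLD-1 cells (Homo sapiens) for cytotoxicity, read by MTT assay; a higher number here means a weaker inhibitor, a lower number a stronger inhibitor:
compound 1 `COc1cc(/C=C/C(=O)C(=Cc2ccc(O)c(O)c2)C(=O)/C=C/c2ccc(O)c(OC)c2)ccc1O` gives 17600 nM
compound 2 `CCOc1ccc(C=C(C(=O)/C=C/c2ccc(O)c(OC)c2)C(=O)/C=C/c2ccc(O)c(OC)c2)cc1OCC` gives 4120 nM
compound 3 `CCOc1cc(/C=C/C(=O)C(=Cc2ccc(OC)c(OC)c2)C(=O)/C=C/c2ccc(O)c(OCC)c2)ccc1O` gives 42000 nM

Compound 3 at 42000 nM has the highest number of the three, above compound 1 and compound 2. The change to compound 4 `CCOc1cc(/C=C/C(=O)C(=Cc2ccc(OCC)c(OCC)c2)C(=O)/C=C/c2ccc(O)c(OCC)c2)ccc1O` is 3,4-diethoxyphenyl in place of 3,4-dimethoxyphenyl on a double-bonded chain carbon bound to a double-bonded chain carbon on a double-bonded chain carbon bound to a double-bonded chain carbon. For the measured compounds named here, one measured step bears on it: a 4.3-fold lower number from compound 1 to compound 2 (0.63 log units; beyond the scatter) with 3,4-diethoxyphenyl in place of 3,4-dihydroxyphenyl at that place. That step is modest, and the group leaving there is a different one. A smaller step towards a lower number is therefore expected in this assay and it may lie little beyond the scatter. The expected change is a 2.1-fold lower number from compound 3 to compound 4 (0.32 log units; beyond the scatter) and no more. The estimate for compound 4 is 20000 nM with an expected range of 7000 nM to 50000 nM as a working figure.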

Compound 4, half-maximal inhibitory concentration: 3450 nM
The estimate for compound 4 lay 5.8-fold (0.76 log units) above the measured number, outside the stated range (below it).
By their numbers in this assay, from the lowest: compounds 4 and 2 (each within the scatter of the next); then compound 1; then compound 3.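

In this assay, 3,4-diethoxyphenyl in place of 3,4-dimethoxyphenyl on a double-bonded chain carbon bound to a double-bonded chain carbon gives a 12-fold lower number from compound 3 to compound 4 (1.09 log units; beyond the scatter). The earlier step, a 4.3-fold lower number from compound 1 to compound 2 (0.63 log units; beyond the scatter), started from 3,4-dihydroxyphenyl and was modest; this one shows that going from methoxy to ethoxy alone at this place is enough for a large step. No measurement offers an explanation for this step.

Open, going by these compounds, is whether a longer chain, such as 3,4-dipropoxyphenyl, extends the trend at this place. On these data alone, how an amine on that phenyl would read is also open.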